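This account rests on a few compounds, and the source may have more. Where it says the series, first, only, none or still open, it means among the compounds named here.

Measured compounds:
- compound 3 `CCc1ccccc1OC1CCN(c2ccc(-n3ccnc3)nn2)CC1`, in an assay on microsomes from liver for inhibition of acyl-CoA desaturase 1 (Rattus norvegicus); a lower number here means a stronger inhibitor, a higher number a weaker inhibitor: 4 nM
- compound 1 `Cc1ccccc1OC1CCN(c2ccc(-n3ccnc3)nn2)CC1`, in this assay: 39 nM
- compound 2 `CC(C)(C)c1nnc(-c2ccc(N3CCC(Oc4ccccc4C(F)(F)F)CC3)nn2)s1`, in this assay: 710 nM

Compound 3 and compound 1 share one core and differ in a single spot: hydrogen in place of methyl on a saturated chain carbon bound to an aromatic carbon. This one change made a step of a 9.8-fold higher number from compound 3 to compound 1 (0.99 log units; beyond the scatter), so losing the methyl weakened the compound to a modest extent.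

Compound 2 stands apart. Its core differs from that of compound 3 in more than one place, and the difference between the two cores is not broken down here. In this assay compound 2 gives the highest number of the three, and the gaps to compound 1 and to compound 3 both lie beyond the usual scatter.

Compound 4 `CC(C)c1nnc(-c2ccc(N3CCC(Oc4ccccc4C(F)(F)F)CC3)nn2)s1` is not yet measured. It is made from compound 2 by hydrogen in place of methyl on a saturated chain carbon bound to an aromatic carbon and two saturated chain carbons. For the measured compounds named here, this is the same kind of change as the one from compound 3 to compound 1, not the same: there the carbon that loses the methyl is bound to an aromatic carbon only, here it is bound to an aromatic carbon and two saturated chain carbons. Resting on the one measured example, compound 4 is expected to be weaker than compound 2, with a step of about a 2.8-fold higher number from compound 2 to compound 4 (0.45 log units; beyond the scatter), though a different core and a different surrounding make the size uncertain. In this assay compound 4 is therefore estimated at 2000 nM, with a likely range from 700 nM to 7000 nM.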

Compound 4, half-maximal inhibitory concentration: 8.8 nM
Estimate against measurement, compound 4: 230-fold (2.36 log units) above, outside the stated range (below it).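

In this assay, cutting the tert-butyl group down to an isopropyl group gave an 81-fold lower number from compound 2 to compound 4 (1.91 log units; beyond the scatter), so here the loss of one methyl made the inhibitor much stronger. The earlier loss of a methyl made the inhibitor weaker, so the same kind of change ran in the opposite direction on the two cores: the same change on two cores in this assay, a 9.8-fold higher number (0.99 log units; beyond the scatter) from compound 3 to compound 1 and an 81-fold lower number (1.91 log units; beyond the scatter) from compound 2 to compound 4, 790-fold (2.90 log units) apart, beyond the scatter of two such steps This shows that neither the size nor the direction of this change carries reliably from one core to the other in this series, but it does not show why: the two cores differ in more than one place, the carbon that loses the methyl has different neighbours in the two pairs, and two steps cannot separate these differences.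

The compounds shown leave open how strength changes along a smaller or differently shaped set of groups in the place of the isopropyl group of compound 4, such as an ethyl, a methyl or a cyclopropyl group. They also leave open whether the change from tert-butyl to isopropyl would give a similar step on a third core, or whether the large step belongs to the pair made up of compound 2 and compound 4 alone.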